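A few compounds are considered here, and "the series" means these few. Any claim that something is new, unique, unknown or untested is made for them only; others in the source may bear on it.

Compound 2 `CC1=CC(=O)N(Nc2nc(-c3cccs3)ncc2-c2nc(C)co2)C1=O` and compound 1 `CC1=CC(=O)N(Nc2nc(-c3cccs3)ncc2-c2nnn(C)n2)C1=O` share one core and differ only in the ring attached to it. In a functional assay on Jurkat cells for inhibition of nuclear factor NF-kappa-B complex (Homo sapiens) (a higher number here means a weaker inhibitor, a lower number a stronger inhibitor), compound 1 gives 200 nM, and in this assay compound 2 gives 200 nM; the step from one to the other, no change at the digits printed from compound 1 to compound 2 (within the scatter), stays within the scatter, so the two stand level. Compound 3 `CC1=CC(=O)N(Nc2nc(-c3cccs3)ncc2C2=NCCO2)C1=O` is the next variation: a group of 5 heavy atoms (3 carbon, 1 nitrogen, 1 oxygen; one five-membered non-aromatic ring with 2 hetero atoms) in place of a group of 6 heavy atoms (4 carbon, 1 nitrogen, 1 oxygen; one five-membered aromatic ring with 2 hetero atoms), on an aromatic carbon. Among the compounds with values here, the only measured step that resembles this change, no change at the digits printed from compound 1 to compound 2 (within the scatter), swapped one five-membered ring for another and moved nothing beyond the scatter. On that evidence a small step is expected for compound 3 in this assay, and if there is any shift it is expected to lean toward weaker inhibition, as a 1.5-fold higher number from compound 2 to compound 3 (0.18 log units; within the scatter). The estimate for compound 3 in this assay is 300 nM, with a plausible range from 100 nM to 900 nM.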

Compound 3, half-maximal inhibitory concentration: 200 nM
Beside the measured number, compound 3's estimate is 1.5-fold (0.18 log units) above it; measured number inside the range.
By their numbers in this assay, from the lowest: compounds 1, 2 and 3 (each within the scatter of the next).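

In this assay, replacing the aromatic ring with a non-aromatic one gives no change at the digits printed from compound 2 to compound 3 (within the scatter), and replacing the tetrazole ring gives no change at the digits printed from compound 1 to compound 3 (within the scatter). Until now, only aromatic five-membered rings had been compared on this aromatic carbon; these steps show that, across these three compounds, the ring need not be aromatic for the value to stay level. Nothing available explains why these three rings read alike.

Going by these compounds, all three groups here are five-membered rings carrying hetero atoms, so it remains open how a phenyl ring, a carboxylic acid or an open chain such as an amine-bearing propyl group would read at this position. The shared thiophen-2-yl group is also unchanged, leaving open whether this level result would hold with a different group there.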